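The source may report more compounds than this note shows. Statements on the series, on what has been measured and on what is new or still open speak of the compounds shown alone.

Measured compounds:
Compound 1, `COc1ccc(C2=C(c3cc(OC)c(OC)c(OC)c3)C(=O)CC2O[SiH2]C(C)(C)C)cc1OC`. In an ADME assay on HEK293 cells (Homo sapiens) for cytotoxicity, read by MTT assay, with a stated time of 72 h (on this read-out higher numbers stand for weaker inhibition and lower numbers for stronger inhibition), compound 1 gives > 100 ug/mL, which is a limit of the assay.
Compound 2, `COc1ccc(C2=C(c3cc(OC)c(OC)c(OC)c3)CC(O[SiH2]C(C)(C)C)C2=O)cc1[N+](=O)[O-]`. In this assay compound 2 gives > 100 ug/mL, again a limit.
Compound 3, `COC(=O)c1cc(C2=C(c3cc(OC)c(OC)c(OC)c3)C(=O)CC2O[SiH2]C(C)(C)C)ccc1OC`. In this assay compound 3 gives > 100 ug/mL, also a limit.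

Compound 3 therefore stands only at a limit, as do the two other values shown; every measured value sits at the limit of > 100 ug/mL in this assay, at which 3 of the 3 values shown sit. Within the data shown here, the one single-point step, a step that the two limits leave unreadable from compound 1 to compound 3, cannot be read because both ends are limits, so no measured step has a readable size.

Compound 4, `COc1ccc(OC)c(C2=C(c3cc(OC)c(OC)c(OC)c3)C(=O)CC2O[SiH2]C(C)(C)C)c1`, is not yet measured. It differs from compound 3 as follows: 2,5-dimethoxyphenyl in place of 4-methoxy-3-(methoxycarbonyl)phenyl on a double-bonded ring carbon.

Among the measured compounds shown here, since the only step that bears on this position is unreadable and all three values rest at the limit, no direction and no size beyond the scatter can be expected for a step that the limit leaves unreadable from compound 3 to compound 4; it is estimated to leave compound 4 at the same limit. The expected result for compound 4 in this assay is 150 ug/mL, with a range from 60 ug/mL to 400 ug/mL, most likely reported as a limit.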

Compound 4, half-maximal inhibitory concentration: 9.5 ug/mL
The estimate for compound 4 lay 16-fold (1.20 log units) above the measured number; the whole stated range lies above it.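

In this assay, the group on the double-bonded ring carbon now has a readable effect, whereas the earlier step between compounds cannot be read. The 2,5-dimethoxyphenyl group gives an at least 10-fold lower number from compound 3 to compound 4 (1.02 log units; beyond the scatter), and in the comparison with 3,4-dimethoxyphenyl it gives an at least 10-fold lower number from compound 1 to compound 4 (1.02 log units; beyond the scatter), so changing where the methoxy groups sit on this aryl ring is enough to produce a step beyond the scatter. Among these compounds, compound 4 is the only compound here with a value that is not a limit: the limit of > 100 ug/mL in this assay, at which 3 of the 4 values shown sit.

Both steps start from limits, so their true sizes remain open, and the compounds shown do not separate the contributions of the two methoxy groups of the 2,5-dimethoxyphenyl group. On these data alone, it also remains open whether an amine or a hydroxyl group in place of either methoxy group would keep the lower number.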